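A Hexyl Amide in Place of the Tetrazolyl Amide

The source may report more compounds than this note shows. Statements on the series, on what has been measured and on what is new or still open speak of the compounds shown alone.

Three compounds sharing one core have been run in a functional assay on K562 cells (Homo sapiens) for cytotoxicity, read by MTT assay, with a stated time of 72 h; a lower number here means a stronger inhibitor, a higher number a weaker inhibitor. Compound 1 `O=C(CN1C(=O)/C(=C/c2ccc(-c3ccc(Cl)cc3)o2)SC1=S)NCc1ccc(C(F)(F)F)cc1` gives 155000 nM. Compound 2 `N#Cc1cc(NC(=O)CN2C(=O)/C(=C/c3ccc(-c4ccc(Cl)cc4)o3)SC2=S)ccc1C(F)(F)F` reaches only a limit of the assay, > 250000 nM, and no number. Compound 3 `O=C(CN1C(=O)/C(=C/c2ccc(-c3ccc(Cl)cc3)o2)SC1=S)Nc1nnn[nH]1` gives 52000 nM, the lowest of the two numbers, compound 1 standing nearest (a 3.0-fold lower number from compound 1 to compound 3 (0.47 log units; beyond the scatter)). Against compound 2 the gap reads an at least 4.8-fold lower number from compound 2 to compound 3 (0.68 log units; beyond the scatter), a step that rests on a limit (the limit of > 250000 nM in this assay, at which 1 of the 3 values shown sits).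

Compound 4 `CCCCCCNC(=O)CN1C(=O)/C(=C/c2ccc(-c3ccc(Cl)cc3)o2)SC1=S` has not been measured in this assay . It differs from compound 3 in one place: hexyl in place of 1H-tetrazol-5-yl on an amide-type nitrogen. Both measured steps into compound 3 show the tetrazolyl amide giving the lower number than either aryl or benzyl amide, so the author expects the hexyl amide of compound 4 to move back toward compound 1, a modest rise, estimated as a 2.3-fold higher number from compound 3 to compound 4 (0.36 log units; beyond the scatter). The expected value for compound 4 is 120000 nM, within 50000 nM to 300000 nM.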

Compound 4, half-maximal inhibitory concentration: 50000 nM
For compound 4 the middle estimate is 2.4-fold (0.38 log units) above the measured one; measured number inside the range.
By their numbers in this assay, from the lowest: compounds 4 and 3 (each within the scatter of the next); then compound 1. At a limit, above all of these: compound 2.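

In this assay, exchanging the 1H-tetrazol-5-yl for hexyl on the amide-type nitrogen gives a 1.0-fold lower number from compound 3 to compound 4 (0.02 log units; within the scatter), so an open chain with no ring and no hydrogen-bond donor serves here as well as the five-membered aromatic ring, and the tetrazolyl amide no longer stands alone at the low end of the series. The 4-(trifluoromethyl)benzyl amide stays apart, with a 3.1-fold lower number from compound 1 to compound 4 (0.49 log units; beyond the scatter). Compound 2 stands at a limit of the assay and has no number, and the step of an at least 5.0-fold lower number from compound 2 to compound 4 (0.69 log units; beyond the scatter) rests on that limit: the limit of > 250000 nM in this assay, at which 1 of the 4 values shown sits.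

The compounds shown leave open whether a butyl chain, a longer chain than hexyl, or a hexyl chain ending in an amine or a carboxylic acid would hold this level. They also leave open how a plain phenyl amide would compare.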